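Carbapenem Prodrug Series: Stability in Phosphate Buffer

A few compounds are considered here, and "the series" means these few. Any claim that something is new, unique, unknown or untested is made for them only; others in the source may bear on it.

Compound 1, `C[C@@H](O)[C@H]1C(=O)N2C(C(=O)OCOC(=O)OC3CCCCC3)=C(S[C@@H]3CN[C@H](C(=O)Nc4cccc(C(=O)O)c4)C3)[C@H](C)[C@H]12`: > 95%
Compound 2, `C[C@@H](O)[C@H]1C(=O)N2C(C(=O)OCC(F)(F)F)=C(S[C@@H]3CN[C@H](C(=O)Nc4cccc(C(=O)OCC(F)(F)F)c4)C3)[C@H](C)[C@H]12`: > 95%

Both measured compounds were run in a physicochemical assay for metabolic stability, read by LC-MS, in phosphate buffer, with a stated time of 3 h, at pH 7.4, tested at 50 uM; on this read-out lower numbers stand for a less stable compound and higher numbers for a more stable compound. Compound 1 comes back only as a limit, > 95%. Compound 2 likewise comes back only as a limit, > 95%. (the limit of > 95% in this assay, at which 2 of the 2 values shown sit). Compound 2 thus stands at the limit, with no number to set it apart from compound 1.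

Compound 3, `C[C@@H](O)[C@H]1C(=O)N2C(C(=O)OCC(F)(F)F)=C(S[C@@H]3CN[C@H](C(=O)Nc4cccc(C(=O)O)c4)C3)[C@H](C)[C@H]12`, is the next step from compound 2: hydrogen in place of 2,2,2-trifluoroethyl on an oxygen next to a carbonyl group. Going by the values given here, no step between two measured compounds is on record, so no size can be taken from a measured pair. Compound 1 carries the same carboxy group and sits at the limit > 95%. On that basis, for compound 3 the step that the limit leaves unreadable from compound 2 to compound 3 is expected to be none beyond the scatter. Compound 3 is expected to give 96%, in the range 88% to 100%, most likely again as a limit.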

Compound 3, percent of the compound remaining: > 95%
Compound 3 was reported as a limit; the forecaster's own chance of this, stated with the estimate: 75%; the middle value does not contradict the limit.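

Neither step to compound 3, from compound 2 or from compound 1, can be read, because each compound returns only a limit in this assay: the limit of > 95% in this assay, at which 3 of the 3 values shown sit.

The compounds shown leave open whether either change alters the read-out at all, as none gives a value short of the limit.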